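The compounds below may be only part of what the source reports. "The series", "measured", "known", "first", "only" and "open" are said of these compounds alone.

Measured so far:
compound 1, `CCCCCCCCc1ccc(OCC(=O)Cn2nnnc2-c2ccccc2Cl)cc1`: 4600 nM
compound 2, `CCCCCCCCc1ccc(OCC(=O)Cn2nnnc2-c2ccc(C(=O)O)cc2)cc1`: 3400 nM

In an assay on microsomes from brain for inhibition of Fatty-acid amide hydrolase 1 (Rattus norvegicus), read by fluorescence and HPLC, with a stated time of 60 min (on this read-out higher numbers stand for weaker inhibition and lower numbers for stronger inhibition), compound 2 gives 3400 nM, the lowest of the two numbers to date; the nearest is compound 1, and the step of a 1.4-fold lower number from compound 1 to compound 2 (0.13 log units; within the scatter) is within the scatter, so the two compounds cannot be ranked. Compound 3, `CCCCCCCCc1ccc(OCC(=O)Cn2nnnc2-c2cccc(C(=O)O)c2)cc1`, is not yet measured. Its change from compound 2 is 3-carboxyphenyl in place of 4-carboxyphenyl on an aromatic carbon. Within the data shown here, the only measured step that bears on it is a 1.4-fold lower number from compound 1 to compound 2 (0.13 log units; within the scatter), which also exchanged the group at this same place on the core and moved the number by less than the scatter. On that single precedent, no step beyond the scatter is expected in this assay for compound 3, in either direction; the expected step is a 1.0-fold higher number from compound 2 to compound 3 (0.01 log units; within the scatter). The number for compound 3 is therefore estimated at 3500 nM, with a range from 1500 nM to 8000 nM, the width reflecting that one step is a thin basis.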

Compound 3, half-maximal inhibitory concentration: 1800 nM
For compound 3 the middle estimate is 1.9-fold (0.29 log units) above the measured one; the measured number falls inside the stated range.
By their numbers in this assay, from the lowest: compounds 3, 2 and 1 (each within the scatter of the next, the first and the last beyond it).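

In this assay, among these compounds, 3-carboxyphenyl in place of 4-carboxyphenyl on the same aromatic carbon gives a 1.9-fold lower number from compound 2 to compound 3 (0.28 log units; within the scatter), so these two isomers, with the same atoms joined differently, cannot be ranked. 3-carboxyphenyl in place of 2-chlorophenyl gives a 2.6-fold lower number from compound 1 to compound 3 (0.41 log units; beyond the scatter), the first step beyond the scatter, though a modest one, whereas the step to the 4-carboxyphenyl compound stays within it: a 1.4-fold lower number from compound 1 to compound 2 (0.13 log units; within the scatter). No measurement bears on the reason for this difference.

Going by these compounds, it remains open whether the separation from compound 1 depends on the carboxylic acid itself, which a 3-chlorophenyl group or a methyl ester at this place would test. Also open, on these data alone, is whether the number would hold with a shorter chain in place of the octyl chain.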